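A few compounds are considered here, and "the series" means these few. Any claim that something is new, unique, unknown or untested is made for them only; others in the source may bear on it.

Two compounds have so far been measured in an assay on isolated protein with sorbitol dehydrogenase (Homo sapiens) as the target; a higher number here means a weaker inhibitor, a lower number a stronger inhibitor:

Compound 1, `Cc1cn(-c2nccc(N3C[C@@H](C)N(c4ccnc([C@@H](C)O)n4)[C@@H](C)C3)n2)c(C)n1`, gives 4 nM in this assay.
Compound 2, `Cc1nc(-c2ccccc2)nc(N2C[C@@H](C)N(c3ccnc([C@@H](C)O)n3)[C@@H](C)C2)n1`, gives 43 nM in this assay.

Compound 2 stands at the higher of these two numbers, which here means the weaker inhibitor. Its gap to compound 1 lies well beyond the usual scatter of repeated measurements, so compound 1 is clearly the stronger of the pair. The two share the same chain of rings on one side but differ in more than one place elsewhere, so they do not show what any single change does.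

Compound 3, `Cc1ncnc(N2C[C@@H](C)N(c3ccnc([C@@H](C)O)n3)[C@@H](C)C2)n1`, has not yet been measured. It differs from compound 2 in one place only: hydrogen in place of phenyl on an aromatic carbon. For the measured compounds named here, no measured pair shows this change on this core, so the direction of the step rests on expectation alone. The step from compound 2 to compound 3 is expected to be modest and toward a higher number, a 2.1-fold higher number from compound 2 to compound 3 (0.32 log units; beyond the scatter), though a result within the scatter of compound 2 would not be surprising. Compound 3 is therefore expected to give about 90 nM in this assay, with a range from 25 nM to 350 nM.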

Compound 3, half-maximal inhibitory concentration: 7 nM
Estimate against measurement, compound 3: 13-fold (1.11 log units) above, and the stated range ends above it.
By their numbers in this assay, from the lowest: compounds 1 and 3 (each within the scatter of the next); then compound 2.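

In this assay, putting hydrogen in place of phenyl on the aromatic carbon between two ring nitrogen atoms gives a 6.1-fold lower number from compound 2 to compound 3 (0.79 log units; beyond the scatter), and a lower number here means a stronger inhibitor. For the compounds shown here, this is the first step that changes one place only, and it shows that on this core the phenyl is not needed for strong inhibition: the compound without it, which has lost a whole aromatic ring of 6 heavy atoms, is clearly the stronger of the pair. No measurement shown here bears on why hydrogen does better than phenyl at this position.

Going by these compounds, only these two substituents can be compared at this carbon, so it remains open where a small group such as an amine or a methoxy group would fall relative to hydrogen and phenyl. This change has also been read on a single pair, which leaves open whether removing a phenyl from this position would give a step of similar direction and size on a different core.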